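The source may report more compounds than this note shows. Statements on the series, on what has been measured and on what is new or still open speak of the compounds shown alone.

Compounds measured in an assay on membranes from HeLa cells for displacement of a labelled ligand from adenosine receptor A3 (Homo sapiens), read by scintillation counting, with a stated time of 180 min, tested at 1 uM; on this read-out lower numbers stand for less inhibition and higher numbers for more inhibition at the one concentration tested (going by the name of the read-out):
compound 1 `CC1=C(C(=O)OC2CCCCC2)C(c2ccoc2)NC(=O)N1`: 1%
compound 2 `CC1=C(C(=O)OC2CCC2)C(c2ccsc2)NC(=O)N1`: 3%

Compound 2 carries the highest number of the two, with compound 1 the nearest, but the two values sit within the scatter of each other, so neither shows more inhibition than the other on this read-out. Both compounds give almost no inhibition at the single concentration.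

Compound 3 `CC1=C(C(=O)OC2CCCCC2)C(c2ccsc2)NC(=O)N1` is not yet measured. It is made from compound 2 by cyclohexyl in place of cyclobutyl on an oxygen next to a carbonyl group. Among the measured compounds shown here, no step between measured compounds covers this change. Since compound 2 gives 3% and compound 1, which already carries cyclohexyl, gives 1%, no movement beyond the scatter is expected; the estimated step is a number 1 percentage points lower from compound 2 to compound 3 (within the scatter). Compound 3 is expected to give about 2%, between -5% and 10%.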

Compound 3, a percentage reported as inhibition, at one concentration (the size of the read-out at that concentration, not a potency): 1%
Compound 3: the middle estimate sits 1 percentage points above what was measured; the measured number falls inside the stated range.
By their numbers in this assay, from the lowest: compounds 1, 3 and 2 (each within the scatter of the next).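

In this assay, the change on the oxygen next to a carbonyl group can now be read directly as a number 2 percentage points lower from compound 2 to compound 3 (within the scatter) and shows no separation of cyclobutyl from cyclohexyl with thiophen-3-yl in place. The change on the saturated ring carbon reads no change at the digits printed from compound 1 to compound 3 (within the scatter) and likewise shows no separation of furan-3-yl from thiophen-3-yl with cyclohexyl in place. No evidence bearing on these results is available.

Going by these compounds, whether an amine or a carboxylic acid on that oxygen would separate from these compounds remains open. So does a phenyl in place of thiophen-3-yl on the saturated ring carbon.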